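This account rests on a few compounds, and the source may have more. Where it says the series, first, only, none or still open, it means among the compounds named here.

In an ADME assay on MT4 cells (Homo sapiens) for cytotoxicity, read by MTT assay, with a stated time of 5 days (on this read-out higher numbers stand for lower toxicity in this test and lower numbers for higher toxicity in this test), compound 1 `CNc1cc(Oc2c(OC)cc3cc(C#N)ccc3c2OC)nc(Nc2ccc(C#N)cc2)n1` gives 239000 nM. Compound 2 `CCCNc1cc(Oc2c(OC)cc3cc(C#N)ccc3c2OC)nc(Nc2ccc(C#N)cc2)n1` reads > 125000 nM, and this reading is a limit of the assay, not a number. Compound 3 `CCCCNc1cc(Oc2c(OC)cc3cc(C#N)ccc3c2OC)nc(Nc2ccc(C#N)cc2)n1` takes the chain one carbon further, propyl to butyl: methyl in place of hydrogen on a saturated chain carbon, three bonds along the chain from a nitrogen on an aromatic ring. Among the compounds with values here, only one measured step bears on this change, a step that the limit leaves unreadable from compound 1 to compound 2, and its size cannot be read. Within the data shown here, no measured step therefore points to a change beyond the scatter in this assay, and none is expected. The expected change is a step that the limit leaves unreadable from compound 2 to compound 3. For compound 3 the estimated value is 150000 nM, with an expected range from 50000 nM to 320000 nM.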

Compound 3, half-maximal cytotoxic concentration: > 125000 nM
Compound 3 ended at the assay's limit; the forecaster's own chance of this, stated with the estimate: 55%; the middle value is on the limit's open side.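

Within the data shown here, no step from compound 2 to compound 3, or from compound 1 to compound 3, can be read, because these comparisons run into a limit of the assay: the limit of > 125000 nM in this assay, at which 2 of the 3 values shown sit. Going by these compounds, the true half-maximal cytotoxic concentrations of compound 2 and compound 3 remain open, as does whether they differ from each other or from compound 1.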